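This account rests on a few compounds, and the source may have more. Where it says the series, first, only, none or still open, it means among the compounds named here.

Of the compounds shown here, two from this series have been measured in a functional assay on ECa-109 cells (Homo sapiens) for cytotoxicity, read by MTT assay, with a stated time of 48 h; a lower number here means a stronger inhibitor, a higher number a weaker inhibitor. Compound 1, with the structure `O=C1C(O)=C(C(c2ccccc2)c2c(-c3ccccc3)[nH]c3ccccc23)C(=O)c2ccccc21`, gives 5180 nM. Compound 2, with the structure `Cc1[nH]c2ccccc2c1C(C1=C(O)C(=O)c2ccccc2C1=O)c1ccc(Cl)cc1`, gives 14300 nM, the higher of the two numbers, and its gap to compound 1 lies beyond the usual scatter. Compound 3, with the structure `Cc1[nH]c2ccccc2c1C(C1=C(O)C(=O)c2ccccc2C1=O)c1ccc([N+](=O)[O-])cc1`, has not yet been measured. It differs from compound 2 in one place: nitro in place of chloro on an aromatic carbon. Among the measured compounds shown here, no pair of measured compounds shows what this change does, so there is no measured step to lean on. For the measured compounds named here, because the only anchor is compound 2 at 14300 nM, a step of no more than the scatter is expected, in either direction. The estimate for compound 3 in this assay is 12000 nM, with a range from 5000 nM to 30000 nM. The expected step is a 1.2-fold lower number from compound 2 to compound 3 (0.08 log units; within the scatter), meaning no change beyond the scatter.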

Compound 3, half-maximal inhibitory concentration: 6000 nM
Compound 3: the middle estimate sits 2.0-fold (0.30 log units) above what was measured; measured number inside the range.
By their numbers in this assay, from the lowest: compounds 1 and 3 (each within the scatter of the next); then compound 2.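

In this assay, among the compounds shown here, changing 4-chlorophenyl to 4-nitrophenyl gives a 2.4-fold lower number from compound 2 to compound 3 (0.38 log units; beyond the scatter), the first measured step at this position. It shows that the group on this aromatic carbon, para to a large group, can move the reading beyond the usual scatter, although the step is modest and rests on a single pair of compounds. Nothing among the data shown explains why the number moves.

Still open, as far as these compounds go, is how other groups at the same place would read, such as an amine, a carboxylic acid or a methoxy group, or a plain hydrogen with no group at all. From the compounds shown here alone, it is also open whether the same swap from chloro to nitro would give a similar step on the core of compound 1.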